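This account rests on a few compounds, and the source may have more. Where it says the series, first, only, none or still open, it means among the compounds named here.

Of the compounds shown here, three have been measured in a physicochemical assay for solubility, read by HPLC, using the shake flask method, measured as kinetic solubility, with a stated time of 2 h, at pH 7.4; a higher number here means a more soluble compound, a lower number a less soluble compound. In this assay compound 1 `Cc1cc(NCc2ccccn2)n2nc(C)c(-c3ccc(F)cc3)c2n1` gives < 5000 nM, which is a limit of the assay and not a number. In this assay compound 2 `Cc1ccc(-c2cnn3c(NCc4ccccn4)cc(C)nc23)cc1` gives < 5000 nM, again a limit. In this assay compound 3 `Cc1cc(Nc2ccccn2)n2nc(C)c(-c3ccccc3)c2n1` gives < 5000 nM, also a limit. Compound 3 therefore stands at the limit of < 5000 nM in this assay, at which 3 of the 3 values shown sit, and no number places it apart from the rest. Among the measured compounds shown here, no step between measured compounds that differ in one place is available in this set. Compound 4 `Cc1cc(NCc2nccs2)n2nc(C)c(-c3ccccc3)c2n1` has not yet been measured; it differs from compound 3 by (1,3-thiazol-2-yl)methyl in place of pyridin-2-yl on a nitrogen on an aromatic ring. With every measured value in this assay resting at the same limit, the data give no direction for this change, and the expected step that the limit leaves unreadable from compound 3 to compound 4 is none beyond the scatter. Compound 4 is expected to give 3000 nM in this assay, within 500 nM to 8000 nM, most probably reported once more as a limit rather than a number.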

Compound 4, solubility: 108000 nM
Estimate against measurement, compound 4: 36-fold (1.56 log units) below; measured number above the stated range.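

In this assay, replacing pyridin-2-yl with (1,3-thiazol-2-yl)methyl on the nitrogen gives an at least 21-fold higher number from compound 3 to compound 4 (1.33 log units; beyond the scatter). Compound 3 gives < 5000 nM, which is a limit of the assay and not a number. Compound 4 alone carries a readable number, so this place on the shared core can lift a compound clear of the limit where the others rest: the limit of < 5000 nM in this assay, at which 3 of the 4 values shown sit.

The step changes the ring and adds the methyl link together, and the compounds shown do not separate these two changes; compound 1 and compound 2 each differ from compound 4 in more than one place. Going by these compounds, whether a longer chain or a morpholine on the same nitrogen would hold the number at the level of compound 4 also remains open.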